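The source may report more compounds than this note shows. Statements on the series, on what has been measured and on what is new or still open speak of the compounds shown alone.

Values in a functional assay on THP-1 cells (Homo sapiens) for inhibition, read by ELISA, with stated times of 2 h and 48 h (on this read-out lower numbers stand for stronger inhibition and higher numbers for weaker inhibition), so far
- compound 1 `CCCCCCCCCCn1cc(/C=[N+](\[O-])c2ccccc2)nn1` gives 9900 nM
- compound 2 `[O-]/[N+](=C\c1cn(CCC(F)(F)C(F)(F)C(F)(F)C(F)(F)C(F)(F)C(F)(F)C(F)(F)C(F)(F)F)nn1)c1ccccc1` gives 11700 nM
- compound 3 `[O-]/[N+](=C\c1cn(CCC(F)(F)C(F)(F)C(F)(F)C(F)(F)C(F)(F)C(F)(F)F)nn1)Cc1ccccc1` gives 12100 nM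

Compound 3 (12100 nM) stands level with the other two, all three values lying within the scatter of one another. Next is compound 4 `[O-]/[N+](=C\c1cn(CCC(F)(F)C(F)(F)C(F)(F)C(F)(F)C(F)(F)C(F)(F)C(F)(F)C(F)(F)F)nn1)Cc1ccccc1`, which differs from compound 3 by one change (1,1,2,2,2-pentafluoroethyl in place of fluoro on a saturated chain carbon bound to two fluorine atoms and a saturated chain carbon): 1,1,2,2,2-pentafluoroethyl in place of fluoro on a saturated chain carbon bound to two fluorine atoms and a saturated chain carbon. With compound 1 (9900 nM) and compound 2 (11700 nM) level with compound 3, no step beyond the scatter is expected in this assay, and neither direction is favoured. The expected step (a 1.1-fold lower number from compound 3 to compound 4 (0.02 log units; within the scatter)) is estimated to stay within the scatter. Compound 4 is estimated at 11500 nM (expected range 5500 nM to 24000 nM).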

Compound 4, half-maximal inhibitory concentration: 17000 nM
Compound 4: the middle estimate sits 1.5-fold (0.17 log units) below what was measured; low and high end bracket the measured number.
By their numbers in this assay, from the lowest: compounds 1, 2, 3 and 4 (each within the scatter of the next).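

In this assay, 1,1,2,2,2-pentafluoroethyl in place of fluoro on this chain carbon gives a 1.4-fold higher number from compound 3 to compound 4 (0.15 log units; within the scatter) and so shows that the position accepts the longer fluorinated chain with the benzyl group in place. Benzyl in place of phenyl on a double-bonded nitrogen, with the chain held constant, gives a 1.5-fold higher number from compound 2 to compound 4 (0.16 log units; within the scatter) and likewise separates nothing. No supporting data bear on either step. Still open, going by these compounds, is whether an amine or a carboxylic acid at the chain end would produce a step beyond the scatter.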